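From chloro to trifluoromethyl: estimating compound 4

A few compounds are considered here, and "the series" means these few. Any claim that something is new, unique, unknown or untested is made for them only; others in the source may bear on it.

Measured in a functional assay on HeLa cells (Homo sapiens) for cytotoxicity, read by MTT assay, with a stated time of 24 h; a higher number here means a weaker inhibitor, a lower number a stronger inhibitor:
compound 1 `CN1C/C(=C\c2ccc(C(F)(F)F)cc2)C(=O)/C(=C/c2ccccc2F)C1` gives 6560 nM
compound 2 `CN1C/C(=C\c2ccc(C(F)(F)F)cc2)C(=O)/C(=C/c2cccc([N+](=O)[O-])c2)C1` gives 3560 nM
compound 3 `CN1C/C(=C\c2ccc(Cl)cc2)C(=O)/C(=C/c2ccc(C#N)cc2)C1` gives 11200 nM

Compound 3 sits within the scatter of compound 1, and its number is higher than that of compound 2, a gap beyond the scatter. Compound 4 `CN1C/C(=C\c2ccc(C#N)cc2)C(=O)/C(=C/c2ccc(C(F)(F)F)cc2)C1` differs from compound 3 by trifluoromethyl in place of chloro on an aromatic carbon. Among the compounds with values here, no measured step covers this exchange. The only one, a 1.8-fold lower number from compound 1 to compound 2 (0.27 log units; within the scatter), involves other groups, so it bears only indirectly. Compound 1 and compound 2 both carry trifluoromethyl, and with compound 1 at 6560 nM and compound 2 at 3560 nM they offer the nearest guide. A small step, not beyond the scatter, is therefore expected in this assay: a 1.6-fold lower number from compound 3 to compound 4 (0.20 log units; within the scatter). For compound 4 the estimated value is 7000 nM, with an expected range of 3000 nM to 15000 nM.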

Compound 4, half-maximal inhibitory concentration: 3210 nM
Estimate against measurement, compound 4: 2.2-fold (0.34 log units) above, within the range that was stated.
By their numbers in this assay, from the lowest: compounds 4, 2, 1 and 3 (each within the scatter of the next, the first and the last beyond it).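

In this assay the exchange of chloro for trifluoromethyl on an aromatic carbon, para to a large group, now has a direct reading (a 3.5-fold lower number from compound 3 to compound 4 (0.54 log units; beyond the scatter)) and lies beyond the scatter. With trifluoromethyl present in all three compounds, 4-cyanophenyl in place of 3-nitrophenyl stays within the scatter (a 1.1-fold lower number from compound 2 to compound 4 (0.04 log units; within the scatter)), whereas 4-cyanophenyl in place of 2-fluorophenyl lies beyond it (a 2.0-fold lower number from compound 1 to compound 4 (0.31 log units; beyond the scatter)). Nothing available explains these steps.

As far as these compounds go, how an amine, a carboxylic acid or a longer chain would compare at this position remains open. So does whether the exchange gives a similar step with other groups on the far side of the shared core.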